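The source may hold more compounds than are shown below. What is called first, only, known or untested is meant among the compounds shown, and "the series" means these compounds.

Working notes on the series, read in a functional assay on HL-60 cells (Homo sapiens) for cytotoxicity, read by ELISA, with a stated time of 2 days; on this read-out higher numbers stand for weaker inhibition and lower numbers for stronger inhibition. On the shared core, compound 1 (`Oc1ccc(-c2cc(-c3ccccc3)cc(-c3cccs3)n2)cc1`) carries thiophen-2-yl and gives 1700 nM. Compound 2 (`Oc1ccc(-c2cc(-c3ccccc3)cc(-c3ccsc3)n2)cc1`) carries thiophen-3-yl and gives 3600 nM. Compound 3 (`Oc1ccc(-c2cc(-c3ccccc3)cc(-c3cccnc3)n2)cc1`) carries pyridin-3-yl and gives 4100 nM. Its nearest neighbour on these numbers shows a 1.1-fold higher number from compound 2 to compound 3 (0.06 log units; within the scatter), a gap within the scatter. Its furthest shows a 2.4-fold higher number from compound 1 to compound 3 (0.38 log units; beyond the scatter), modest but beyond the scatter.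

Next is compound 4 (`Oc1ccc(-c2cc(-c3ccccc3)cc(-c3ccc(O)cc3)n2)cc1`): 4-hydroxyphenyl in place of pyridin-3-yl on an aromatic carbon. The swap sits on an aromatic carbon next to the ring nitrogen, the same place that varies across the measured compounds. The steps at this place are therefore the guide, and the largest of them is the modest one to compound 3; the other is a 2.1-fold higher number from compound 1 to compound 2 (0.33 log units; beyond the scatter). Among the measured compounds shown here, no measured compound carries 4-hydroxyphenyl at this place, so the direction remains open, and no large step is expected. The expected step is a 1.4-fold lower number from compound 3 to compound 4 (0.14 log units; within the scatter), which is no clear shift beyond the scatter. Compound 4 is estimated at 3000 nM, with an expected range of 1100 nM to 8000 nM.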

Compound 4, half-maximal inhibitory concentration: 5700 nM
For compound 4 the middle estimate is 1.9-fold (0.28 log units) below the measured one, within the range that was stated.
By their numbers in this assay, from the lowest: compound 1; then compounds 2, 3 and 4 (each within the scatter of the next).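

In this assay, a six-membered aromatic ring of carbon only is now tested at this place, and 4-hydroxyphenyl in place of pyridin-3-yl gives a 1.4-fold higher number from compound 3 to compound 4 (0.14 log units; within the scatter), while in place of thiophen-3-yl it gives a 1.6-fold higher number from compound 2 to compound 4 (0.20 log units; within the scatter), so the ring nitrogen of pyridin-3-yl is not needed to stay within the scatter of these two compounds. Only thiophen-2-yl stands apart, with a 3.4-fold higher number from compound 1 to compound 4 (0.53 log units; beyond the scatter), which leaves compound 1 the most potent of the four in this assay. Nothing on hand bears on why these groups read as they do.

As far as these compounds go, whether an amine, a carboxylic acid or a longer chain at this place would move the number beyond the scatter stays open. The compounds shown also leave open whether thiophen-2-yl keeps its edge when another group replaces the phenyl group.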